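Chloro to Bromo, Read Against One Measured Step

The source may hold more compounds than are shown below. What is called first, only, known or untested is meant among the compounds shown, and "the series" means these compounds.

Compound 1 `O=[N+]([O-])c1ccc2[nH]cc(C(c3ccc(Cl)cc3)c3c[nH]c4ccc([N+](=O)[O-])cc34)c2c1`: > 100000 nM
Compound 2 `O=[N+]([O-])c1ccc2[nH]cc(C(c3ccc(Br)cc3)c3c[nH]c4ccc([N+](=O)[O-])cc34)c2c1`: > 100000 nM
Compound 3 `N#Cc1ccc2[nH]cc(C(c3ccc(Cl)cc3)c3c[nH]c4ccc(C#N)cc34)c2c1`: 23600 nM

Of the compounds shown here, three have been tested in a functional assay on MCF7 cells (Homo sapiens) for inhibition, read by MTT assay, with a stated time of 48 h; a higher number here means a weaker inhibitor, a lower number a stronger inhibitor. Compound 1 reaches only a limit of the assay, > 100000 nM, and not a number. Compound 2 likewise stops at a limit, > 100000 nM. Compound 3 is the one that gives a real number, 23600 nM. The difference between the core of compound 1 and the core of compound 3 is not broken down here.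

Compound 1 and compound 2 differ in one place, (bromo in place of chloro on an aromatic carbon). The step in this assay, a step that the two limits leave unreadable from compound 1 to compound 2, cannot be sized, because of the limit of > 100000 nM in this assay, at which 2 of the 3 values shown sit.

Compound 4 `N#Cc1ccc2[nH]cc(C(c3ccc(Br)cc3)c3c[nH]c4ccc(C#N)cc34)c2c1` has not been measured in this assay. It stands to compound 3 as compound 2 stands to compound 1: bromo in place of chloro on an aromatic carbon. This is the same change, at the same kind of place. For the measured compounds named here, the only measured instance of it gives no readable size, so the expectation for compound 4 rests mainly on compound 3 and its value of 23600 nM, with a step of a 1.2-fold lower number from compound 3 to compound 4 (0.07 log units; within the scatter) expected. Compound 4 is therefore expected to fall near 20000 nM, within a range from 7000 nM to 60000 nM.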

Compound 4, half-maximal inhibitory concentration: 27100 nM
For compound 4 the middle estimate is 1.4-fold (0.13 log units) below the measured one, and the stated range covers the measured number.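

In this assay, replacing the 4-chlorophenyl group with a 4-bromophenyl group on the core of compound 3 gives a 1.1-fold higher number from compound 3 to compound 4 (0.06 log units; within the scatter), so on this core the change leaves the reading within the usual scatter of repeated measurements. This is the only readable size for the change, since the matching step on the core of compound 1 cannot be read because both compounds on that core stop at a limit of the assay and give no number: the limit of > 100000 nM in this assay, at which 2 of the 4 values shown sit. The new step therefore shows what the change does on one core, but it does not show that the change carries from one core to the other, and the two cores may or may not respond alike.

Among the compounds shown, only chloro and bromo occupy this place on the aromatic ring, so what an amine, a carboxylic acid or a longer chain such as butyl would give there remains open. Also open, as far as these compounds go, is how the same swap of chloro for bromo would read on a core carrying an amide or a methyl ester in place of the nitro or nitrile groups.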